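Opening the aminocyclopentyl ring in the oxadiazole series

This account rests on a few compounds, and the source may have more. Where it says the series, first, only, none or still open, it means among the compounds named here.

Measured so far:
- compound 1, `CCCCCCCCCCc1ccc(-c2noc(CCCN)n2)cc1`: 67%
- compound 2, `CCCCCCCCCCc1ccc(-c2noc(CCCNC)n2)cc1`: 45%
- compound 3, `CCCCCCCCCCc1ccc(-c2noc([C@@H]3CC[C@H](N)C3)n2)cc1`: 38%

All three were run in an assay on HeLa cells for inhibition of sphingosine-1-phosphate transporter SPNS2 (Mus musculus), read by LC-MS, tested at 2 uM; a higher number here means more inhibition at the concentration tested (going by the name of the read-out), a lower number less inhibition. Compound 3 carries the lowest number of the three, but the nearest step to it is a number 7 percentage points lower from compound 2 to compound 3 (within the scatter), so no order between those two is claimed; only compound 1 sits clearly apart, with a number 29 percentage points lower from compound 1 to compound 3 (beyond the scatter).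

Compound 4, `CCCCCCCCCCc1ccc(-c2noc([C@@H](N)CCCCN)n2)cc1`, is not yet measured. It differs from compound 3 as follows: 1,5-diaminopentyl in place of 3-aminocyclopentyl on an aromatic carbon.

Going by the values given here, no measured step mirrors this change. Among the compounds with values here, the nearest pointers are a number 29 percentage points lower from compound 1 to compound 3 (beyond the scatter), where the ring took the place of an open 3-aminopropyl chain, and a number 22 percentage points lower from compound 1 to compound 2 (beyond the scatter), where a methyl on the amine nitrogen was the only change. Both were modest losses. Compound 4 returns to an open chain but adds a second amine and moves one amine onto the carbon bearing the aromatic ring, so the outcome cannot be read off directly.

A modest recovery toward the level of compound 1 is expected, a number 17 percentage points higher from compound 3 to compound 4 (beyond the scatter), with wide uncertainty. Compound 4 is estimated at 55%, between 30% and 80%.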

Compound 4, a percentage reported as inhibition, at one concentration (the size of the read-out at that concentration, not a potency): 43%
For compound 4 the middle estimate is 12 percentage points above the measured one; measured number inside the range.
By their numbers in this assay, from the lowest: compounds 3, 4 and 2 (each within the scatter of the next); then compound 1.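

In this assay, a number 5 percentage points higher from compound 3 to compound 4 (within the scatter), so exchanging 3-aminocyclopentyl for 1,5-diaminopentyl, which removes the ring and brings in a second amine, gives no readable difference at this position on the aromatic carbon. The open chain alone therefore does not restore the level of compound 1: a number 24 percentage points lower from compound 1 to compound 4 (beyond the scatter), while a number 2 percentage points lower from compound 2 to compound 4 (within the scatter), which places compound 4 with compounds 2 and 3 and leaves compound 1, with its 3-aminopropyl group, clearly apart from all three. No supporting data bear on why the numbers fall this way.

The compounds shown do not separate the effect of the second amine from that of the longer open chain, as compound 4 differs from compound 1 in both, so a 5-aminopentyl chain carrying a single amine would be the informative comparison alongside compound 1 and compound 4. From the compounds shown here alone, it also stays open whether the mirror-image arrangement at the single defined stereocentre of 1,5-diaminopentyl would read any differently from compound 4 at this one tested concentration.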